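A few compounds are considered here, and "the series" means these few. Any claim that something is new, unique, unknown or untested is made for them only; others in the source may bear on it.

Of the compounds shown here, two built on the same fused two-ring core have been tested in an assay on cells for inhibition of Indoleamine 2,3-dioxygenase 1 (Homo sapiens); on this read-out lower numbers stand for stronger inhibition and higher numbers for weaker inhibition. Compound 1 `O=C(CSc1nnc2scc(-c3ccc(Cl)cc3)n12)c1ccc(Br)cc1` gives 339 nM in this assay. Compound 2 `CC(C)CSc1nnc2scc(-c3ccc(Cl)cc3)n12` gives 256 nM in this assay. Compound 1 thus holds the higher of the two numbers shown, but its distance from compound 2 lies within the scatter of the measurement, so the two values cannot be told apart with confidence.

Compound 3 `O=C(CSc1nnc2scc(C3CCCCC3)n12)c1ccc(Br)cc1` is the next member and has not yet been measured. It differs from compound 1 in one place: cyclohexyl in place of 4-chlorophenyl on an aromatic carbon, in words a cyclohexyl in place of a 4-chlorophenyl on an aromatic carbon. For the measured compounds named here, no pair of measured compounds shows a step of this kind, so nothing measured here tells how large a change to expect. Swapping a chlorine-bearing aromatic ring for a saturated carbon ring is a substantial structural change, and a step beyond the scatter, most likely toward weaker inhibition, is expected. For compound 3 the expected value in this assay is 700 nM, with a range from 250 nM to 2500 nM, which amounts to an expected step of a 2.1-fold higher number from compound 1 to compound 3 (0.31 log units; beyond the scatter).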

Compound 3, half-maximal inhibitory concentration: > 10000 nM
Compound 3 was reported as a limit (the forecaster's own chance of this, stated with the estimate: 5%); middle value at least 14-fold (1.15 log units) from the limit.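

Compound 3 is reported only as a limit of the assay, not as an exact number: the limit of > 10000 nM in this assay, at which 1 of the 3 values shown sits. Even so, exchanging 4-chlorophenyl for cyclohexyl on this aromatic carbon gives an at least 29-fold higher number from compound 1 to compound 3 (1.46 log units; beyond the scatter) in this assay, showing that inhibition depends strongly on the group at this position, something compounds 1 and 2 could not reveal because both carry 4-chlorophenyl there. The entering cyclohexyl is also a six-membered ring of carbon only, so in this pair, a carbon ring of that size is not enough on its own to retain measurable inhibition up to the limit.

This single step changes two things at once, removing both the chlorine and the aromatic character of the ring, so the compounds shown cannot say which loss matters more or whether both are needed. An unsubstituted phenyl would separate these two features, while a 4-fluorophenyl or 4-methoxyphenyl would show whether the chlorine can be replaced, and the limit leaves the true size of the step for compound 3 unknown.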